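The compounds below may be only part of what the source reports. "The series", "measured", "known", "first", "only" and "open" are said of these compounds alone.

Working notes on the series.

Three flavone glycosides have numbers in a functional assay (Homo sapiens) for inhibition, in the presence of a further agent that is not named here; a higher number here means a weaker inhibitor, a lower number a stronger inhibitor. Compound 1 `COc1ccc(-c2cc(=O)c3c(O)c(OC)c(O[C@@H]4O[C@H](CO[C@@H]5O[C@@H](C)[C@H](O)[C@@H](OC(C)=O)[C@H]5O)[C@@H](O)[C@H](O)[C@H]4O)cc3o2)cc1` gives 15600 nM in this assay. Compound 2 `COc1ccc(-c2cc(=O)c3c(O)c(OC)c(O[C@@H]4OC(CO[C@@H]5OC(C)[C@H](O)[C@H](O)C5OC(C)=O)[C@@H](O)[C@H](O)C4O)cc3o2)cc1` gives 11800 nM, and compound 3 `COC1=C(O)C2=C(O)C=C(c3ccc(OC)cc3)OC2=CC1OC1OC(O)C(O)C(O)C1O` gives 8900 nM. Compound 1 has the highest of the three numbers, but its gap to compound 2 and its gap to compound 3 both lie within the usual scatter of this assay, so the three compounds cannot be ranked on these data.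

Compound 4 `COc1ccc(-c2cc(=O)c3c(O)c(OC)c(O[C@@H]4OC(CO[C@@H]5OC(C)[C@H](O)[C@H](OC(C)=O)C5O)[C@@H](O)[C@H](O)C4O)cc3o2)cc1` is not yet measured. Relative to compound 1 the difference is the two compounds have the same atoms and bonds; at least one stereo element is drawn with a configuration in one of them and without one in the other: 5 of 10 stereo elements differ; a stereocentre at a saturated ring carbon is drawn R in compound 1 and without a configuration in compound 4; a stereocentre at a saturated ring carbon is drawn S in compound 1 and without a configuration in compound 4; a stereocentre at a saturated ring carbon is drawn R in compound 1 and S in compound 4; a stereocentre at a saturated ring carbon is drawn R in compound 1 and without a configuration in compound 4. The two compounds share every atom and bond; the change lies only in how the sugar stereocentres are drawn, with one inversion and several left unspecified. Among the compounds with values here, no step between measured compounds exists that separates such a change in stereochemical drawing from the rest of the structure, so no direction can be read off for it. The expectation is therefore that the step from compound 1 to compound 4, a 1.1-fold lower number from compound 1 to compound 4 (0.05 log units; within the scatter), is none beyond the scatter of this assay. On that basis compound 4 is estimated at 14000 nM in this assay, within a range of 7000 nM to 28000 nM.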

Compound 4, half-maximal inhibitory concentration: 21500 nM
Beside the measured number, compound 4's estimate is 1.5-fold (0.19 log units) below it; measured number inside the range.
By their numbers in this assay, from the lowest: compounds 3, 2, 1 and 4 (each within the scatter of the next, the first and the last beyond it).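

In this assay, within the data shown here, the sugar stereocentres now have a step of their own, a 1.4-fold higher number from compound 1 to compound 4 (0.14 log units; within the scatter), whereas the earlier compounds offered no pair differing in one place. One inversion and the unspecified centres, taken together, therefore leave no readable mark in this assay. The step cannot be assigned to any single centre, because the comparison rests on an incomplete drawing: the fact that one of compounds 1 and 4 is drawn with a defined configuration and the other without, at the place where they differ.

Still open is whether two fully assigned sugar epimers would separate in this assay, since no pair shown has every centre defined on both sides. Also open, on these data alone, is whether an amine or a carboxylic acid in place of the acetyl ester on the sugar would give a step beyond the scatter.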